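The source may report more compounds than this note shows. Statements on the series, on what has been measured and on what is new or still open speak of the compounds shown alone.

Compound 1 `COc1ccc(S(=O)(=O)c2cnc3ccc(F)cc3c2N2CCC(C)CC2)cc1` and compound 2 `CC1CCN(c2c(S(=O)(=O)c3ccc(Cl)cc3)cnc3ccc(F)cc23)CC1` share one core and differ only at the aromatic carbon bearing methoxy or chloro. In an assay on isolated protein for displacement of a labelled ligand from metabotropic glutamate receptor 5 (Homo sapiens), with a stated time of 60 min, tested at 1 uM (a lower number here means less inhibition, a higher number more inhibition at the concentration tested (going by the name of the read-out)), compound 1 gives 85%, and in this assay compound 2 gives 80%; the step of a number 5 percentage points lower from compound 1 to compound 2 (within the scatter) lies within the scatter, so compound 2 stands beside compound 1 with no separation the numbers can support. Compound 3 `CC1CCN(c2c(S(=O)(=O)c3cccc(C#N)c3)cnc3ccc(F)cc23)CC1` carries the change (3-cyanophenyl in place of 4-chlorophenyl on a sulfonyl sulfur). For the measured compounds named here, only the single measured step bears on this, and it was small; a similar outcome is therefore expected, with the step of a number 5 percentage points lower from compound 2 to compound 3 (within the scatter). Compound 3 is estimated at 75%, between 55% and 92%.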

Compound 3, a percentage reported as inhibition, at one concentration (the size of the read-out at that concentration, not a potency): 93%
Compound 3: the middle estimate sits 18 percentage points below what was measured; the measured number lies above the stated range.
By their numbers in this assay, from the lowest: compounds 2, 1 and 3 (each within the scatter of the next, the first and the last beyond it).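

For the compounds shown here, at this place, on a sulfonyl sulfur, this assay now shows a number 13 percentage points higher from compound 2 to compound 3 (beyond the scatter) for 3-cyanophenyl in place of 4-chlorophenyl, the first step to pass the scatter. Set against 4-methoxyphenyl, the same group gives a number 8 percentage points higher from compound 1 to compound 3 (within the scatter) and so stands apart from only one of the two earlier aryl groups. Nothing at hand accounts for this step.

As far as these compounds go, whether the nitrile or its place on the ring carries the step stays open. So does what a carboxylic acid or an amine on that phenyl ring would give.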